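Dropping the fluoro: cytotoxicity outlook for compound 3

This account rests on a few compounds, and the source may have more. Where it says the series, first, only, none or still open, it means among the compounds named here.

Going by the values given here, in an ADME assay on L6 cells (Rattus norvegicus) for cytotoxicity (on this read-out lower numbers stand for stronger inhibition and higher numbers for weaker inhibition), compound 1 `CC(=O)Nc1ccc(S(=O)(=O)N2c3ccccc3CCC2C)cc1` gives 52000 nM and compound 2 `CC1CCc2ccccc2N1S(=O)(=O)c1ccc(F)cc1` gives 67600 nM; the step of a 1.3-fold higher number from compound 1 to compound 2 (0.11 log units; within the scatter) is the only change measured so far. Compound 2 holds the highest of the two numbers, with compound 1 nearest, within the scatter. Compound 3 `CC1CCc2ccccc2N1S(=O)(=O)c1ccccc1` differs from compound 2 by hydrogen in place of fluoro on an aromatic carbon. Among the compounds with values here, no measured step matches this change exactly; the one step, a 1.3-fold higher number from compound 1 to compound 2 (0.11 log units; within the scatter), exchanged the group on that aromatic carbon without moving the number beyond the scatter. For compound 3 no step beyond the scatter is therefore expected in this assay, and compound 3 is estimated at 75000 nM with a range of 35000 nM to 160000 nM, meaning a 1.1-fold higher number from compound 2 to compound 3 (0.05 log units; within the scatter).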

Compound 3, half-maximal inhibitory concentration: 70000 nM
For compound 3 the middle estimate is 1.1-fold (0.03 log units) above the measured one; low and high end bracket the measured number.
By their numbers in this assay, from the lowest: compounds 1, 2 and 3 (each within the scatter of the next).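

In this assay the fluoro can be replaced by hydrogen on this aromatic carbon with the change staying within the scatter (a 1.0-fold higher number from compound 2 to compound 3 (0.02 log units; within the scatter)). Going by these compounds alone, compound 3 also gives the first direct comparison of acetamido with hydrogen at this carbon, and that change too stays within the scatter (a 1.3-fold higher number from compound 1 to compound 3 (0.13 log units; within the scatter)). Acetamido, fluoro and hydrogen therefore cannot be separated here, and no supporting data bear on why.

As far as these compounds go, whether an amine or a carboxylic acid on this aromatic carbon would move the number beyond the scatter remains open. So does the effect of changes elsewhere on the shared core.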